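Phenyl for Propyl on the Chain of Compound 2

The source may hold more compounds than are shown below. What is called first, only, known or untested is meant among the compounds shown, and "the series" means these compounds.

Compound 2 `CCCC/N=C(\S)OC[C@H]1OC(n2cnc3c(NC4CCOC4)ncnc32)[C@H](O)[C@@H]1O` gives 157 nM in an assay on DDT1 cells (Cricetulus griseus) for binding affinity to adenosine receptor A1 (Homo sapiens), read by radioligand binding; on this read-out lower numbers stand for stronger inhibition and higher numbers for weaker inhibition. Compound 3 `O[C@@H]1[C@@H](CO/C(S)=N/C2CC2)OC(n2cnc3c(NC4CCOC4)ncnc32)[C@@H]1O` gives 157 nM, level with compound 2 within the scatter, and together these two show the highest numbers among the three measured compounds. Compound 1 `CNC(=O)OC[C@H]1OC(n2cnc3c(NC4CCOC4)nc(Cl)nc32)[C@H](O)[C@@H]1O` gives 96 nM, the furthest from compound 2 yet still within the scatter. Compound 4 `O[C@@H]1[C@@H](CO/C(S)=N/Cc2ccccc2)OC(n2cnc3c(NC4CCOC4)ncnc32)[C@@H]1O` has not been measured. Its change from compound 2 is phenyl in place of propyl on a saturated chain carbon bound to a double-bonded nitrogen. Among the compounds with values here, only one measured step bears on it, the exchange of butyl for cyclopropyl on the double-bonded nitrogen, where no change at the digits printed from compound 2 to compound 3 (within the scatter). On that basis no step beyond the scatter is expected for compound 4, a 1.1-fold lower number from compound 2 to compound 4 (0.05 log units; within the scatter). Compound 4 is therefore estimated at 140 nM, with a range from 50 nM to 400 nM.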

Compound 4, inhibition constant: 12 nM
For compound 4 the middle estimate is 12-fold (1.07 log units) above the measured one; measured number outside the range, below it.
By their numbers in this assay, from the lowest: compound 4; then compounds 1, 2 and 3 (each within the scatter of the next).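

In this assay the group on the double-bonded nitrogen turns out to matter: butyl to benzyl brings a 13-fold lower number from compound 2 to compound 4 (1.12 log units; beyond the scatter) and cyclopropyl to benzyl brings a 13-fold lower number from compound 3 to compound 4 (1.12 log units; beyond the scatter) as a large step, whereas the exchange of butyl for cyclopropyl had moved nothing beyond the scatter. Among these groups, only benzyl separates from the others. Nothing given here accounts for this step.

The compounds shown leave open whether phenethyl, with a longer chain before the phenyl, would hold this lower number, and whether pyridylmethyl could replace benzyl.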